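Para substituent swap on the carboxylic acid chromenone series

A few compounds are considered here, and "the series" means these few. Any claim that something is new, unique, unknown or untested is made for them only; others in the source may bear on it.

Measured compounds in a functional assay on the whole organism (stomach) for inhibition, with Rattus norvegicus as the target, at a dose of 80 mg/kg; a higher number here means more inhibition at the dose given (going by the name of the read-out), a lower number less inhibition:
- compound 1, `COc1ccc(-c2cc(=O)c3cc(C(=O)O)ccc3o2)cc1`, gives 13%
- compound 2, `O=C(O)c1ccc2oc(-c3ccc(F)cc3)cc(=O)c2c1`, gives 21%
- compound 3, `Cc1ccc(-c2oc3ccc(C(=O)O)cc3c(=O)c2O)cc1`, gives 6%

Compound 3 sits within the scatter of compound 1 and is separated from compound 2 by a gap beyond the scatter, so the three numbers do not order compound 3 against compound 1, only against compound 2.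

Compound 4, `O=C(O)c1ccc2oc(-c3ccc(Cl)cc3)c(O)c(=O)c2c1`, differs from compound 3 by chloro in place of methyl on an aromatic carbon. Going by the values given here, the only measured step, a number 8 percentage points higher from compound 1 to compound 2 (within the scatter), also exchanges the group on that aromatic carbon of the pendant ring, and it stayed within the scatter. Among the compounds with values here, no step with a chloro or a hydroxylated core is measured. A step of similar modest size is therefore expected, a number 6 percentage points higher from compound 3 to compound 4 (within the scatter), with no firm direction. Compound 4 is estimated at 12%, between 0% and 28%.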

Compound 4, a percentage reported as inhibition, in the whole organism at one dose (the size of the read-out at that dose, not a potency): -19%
Compound 4: middle estimate off by 31 percentage points, on the high side; measured number outside the range, below it.
By their numbers in this assay, from the lowest: compound 4; then compounds 3, 1 and 2 (each within the scatter of the next, the first and the last beyond it).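

Notes on the pendant ring: in this assay the change from 4-methylphenyl to 4-chlorophenyl gives a number 25 percentage points lower from compound 3 to compound 4 (beyond the scatter) on the hydroxylated core. Going by these compounds alone, an exchange at this position can therefore move the read-out beyond the scatter, unlike a number 8 percentage points higher from compound 1 to compound 2 (within the scatter) on the core of compound 1, and compound 4 gives -19%, the only negative number in the set. No measurement at hand explains this step.

Open, as far as these compounds go, is whether chloro gives a similar step on the core of compound 1. Also open, from the compounds shown here alone, is how a trifluoromethyl or an amine at this position would read out on either core.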